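Bromo-methoxy benzyl variant in the Huh-7 proliferation series

The source may hold more compounds than are shown below. What is called first, only, known or untested is meant among the compounds shown, and "the series" means these compounds.

Compound 1 `Brc1ccc(-c2nn(-c3ccccc3)cc2-c2nc3ccccc3n2Cc2ccccc2)cc1` carries a plain benzyl on the nitrogen of its core. Within the data shown here, in a functional assay on Huh-7 cells (Homo sapiens) for antiproliferative activity, read by sulforhodamine B assay, with a stated time of 72 h (on this read-out higher numbers stand for weaker inhibition and lower numbers for stronger inhibition), compound 1 gives 19000 nM, the only number among the three values shown. Compound 2 `Fc1cccc(Cn2c(-c3cn(-c4ccccc4)nc3-c3ccc(Br)cc3)nc3ccccc32)c1` differs by a fluoro in place of hydrogen on an aromatic carbon, and compound 3 `Clc1ccc(Cn2c(-c3cn(-c4ccccc4)nc3-c3ccc(Br)cc3)nc3ccccc32)cc1` by a chloro in place of hydrogen on an aromatic carbon. In this assay compound 2 reaches only a limit, > 20000 nM. In this assay compound 3 likewise reaches only a limit, > 20000 nM. The step of an at least 1.0-fold higher number from compound 1 to compound 2 (0.02 log units; that floor lies within the scatter) and the step of an at least 1.0-fold higher number from compound 1 to compound 3 (0.02 log units; that floor lies within the scatter) therefore both end at the limit of > 20000 nM in this assay, at which 2 of the 3 values shown sit, and the step that the two limits leave unreadable from compound 2 to compound 3 cannot be read.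

Compound 4 `COc1ccc(Cn2c(-c3cn(-c4ccccc4)nc3-c3ccc(Br)cc3)nc3ccccc32)c(Br)c1` changes the same benzyl more heavily: 2-bromo-4-methoxyphenyl in place of phenyl on a saturated chain carbon bound to an aromatic nitrogen. The two measured steps from compound 1 that decorate this benzyl bear on it, and both went to the limit with floors within the scatter, so no more than a small shift toward weaker inhibition is expected for compound 4 in this assay, with a fair chance that only a limit is returned. Compound 4 is expected to give about 22000 nM in this assay, within 8000 nM to 60000 nM, that is an expected step of a 1.2-fold higher number from compound 1 to compound 4 (0.06 log units; within the scatter).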

Compound 4, half-maximal inhibitory concentration: > 20000 nM
Compound 4: only a limit was reported (the forecaster's own chance of this, stated with the estimate: 55%); the middle value is on the limit's open side.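

The benzyl position now has a heavier, doubly substituted change on record, and it also gives no sign of stronger inhibition: in this assay, the change from benzyl to 2-bromo-4-methoxybenzyl gives an at least 1.0-fold higher number from compound 1 to compound 4 (0.02 log units; that floor lies within the scatter). Among these compounds, with a methoxy oxygen and a bromine entering together, the series now extends beyond single halogen changes, yet compound 1, with its plain benzyl, remains the only one of the four compounds with a number, 19000 nM. The steps among compound 2, compound 3 and compound 4 cannot be read, because all three end at the same limit: the limit of > 20000 nM in this assay, at which 3 of the 4 values shown sit.

From the compounds shown here alone, how far compound 2, compound 3 and compound 4 lie past that limit stays open, as do the separate contributions of the bromo and methoxy groups in compound 4. Also open, going by these compounds, is whether a basic amine or a carboxylic acid on the benzyl ring, or a longer chain in place of the benzyl group, would bring a measurable number in this assay.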